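Fused ring variation on the shared core: clearance notes

The source may hold more compounds than are shown below. What is called first, only, known or untested is meant among the compounds shown, and "the series" means these compounds.

Measured compounds in an ADME assay on cells (Hepatocyte, Rattus norvegicus) for metabolic stability, using equilibrium dialysis; on this read-out higher numbers stand for fast clearance and lower numbers for slow clearance:
compound 1 `CC(=O)N[C@@H]1CCC[C@H](C(=O)Nc2cc(-c3cnn4c3CCC4)c(Cl)cn2)C1` gives 72 uL/min
compound 2 `CC(=O)N[C@@H]1CCC[C@H](C(=O)Nc2cc(-c3cnn4c3CCCCC4)c(Cl)cn2)C1` gives 51 uL/min
compound 3 `CC(=O)N[C@@H]1CCC[C@H](C(=O)Nc2cc(-c3cnn4c3COCC4)c(Cl)cn2)C1` gives 18 uL/min

Compound 3 stands lowest of the three numbers in this assay; its nearest neighbour is compound 2 at a 2.8-fold lower number from compound 2 to compound 3 (0.45 log units; beyond the scatter), and the furthest is compound 1 at a 4.0-fold lower number from compound 1 to compound 3 (0.60 log units; beyond the scatter). The step from compound 1 to compound 2 is a 1.4-fold lower number from compound 1 to compound 2 (0.15 log units; within the scatter).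

Compound 4 `CC(=O)N[C@@H]1CCC[C@H](C(=O)Nc2cc(-c3cnn4c3NCCC4)c(Cl)cn2)C1` is the next member. It differs from compound 3 in this way: a group of 9 heavy atoms (6 carbon, 3 nitrogen; one five-membered aromatic ring with 2 hetero atoms, one six-membered non-aromatic ring with 2 hetero atoms) in place of a group of 9 heavy atoms (6 carbon, 2 nitrogen, 1 oxygen; one five-membered aromatic ring with 2 hetero atoms, one six-membered non-aromatic ring with 2 hetero atoms), on an aromatic carbon.

The two steps that bear on this change are those that alter the same fused ring, from compound 1 to compound 3 and from compound 2 to compound 3, both modest. Among the compounds with values here, neither exchanges an oxygen for a nitrogen, so no measured step speaks directly to the present change, and the expectation is for no movement beyond the scatter, with the number for compound 4 estimated near compound 3, the step being a 1.2-fold higher number from compound 3 to compound 4 (0.09 log units; within the scatter).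

Compound 4 is expected to give 22 uL/min in this assay, with a range from 9 uL/min to 50 uL/min.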

Compound 4, intrinsic clearance in a liver preparation (reported as CLH), per the amount of preparation that the assay uses: 10 uL/min
The estimate for compound 4 lay 2.2-fold (0.34 log units) above the measured number; the measured number falls inside the stated range.
By their numbers in this assay, from the lowest: compounds 4 and 3 (each within the scatter of the next); then compounds 2 and 1 (each within the scatter of the next).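

In this assay, putting the group with 1 hydrogen-bond donor and a third nitrogen in place of the oxygen-bearing group leaves the number within the scatter (a 1.8-fold lower number from compound 3 to compound 4 (0.26 log units; within the scatter)), so at this aromatic carbon, ortho to the chloro group, oxygen and nitrogen in the six-membered ring are not told apart here. The nitrogen-bearing ring also stands clear of both rings with 1 hetero atom (a 5.1-fold lower number from compound 2 to compound 4 (0.71 log units; beyond the scatter); a 7.2-fold lower number from compound 1 to compound 4 (0.86 log units; beyond the scatter)), so among these four compounds, with none going against it, both six-membered rings with 2 hetero atoms give the lower numbers. No measurement shown accounts for these differences.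

Ring size and the second hetero atom change together in these steps, so their shares remain unresolved. A six-membered ring with 1 hetero atom, or a methyl on the added ring nitrogen of compound 4, would bear on both questions.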